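Series notes: methoxy for trifluoromethyl on the benzyl amide

The source may report more compounds than this note shows. Statements on the series, on what has been measured and on what is new or still open speak of the compounds shown alone.

Three compounds of the shared core have numbers in an assay on cells for inhibition of phosphatidylcholine:ceramide cholinephosphotransferase 2 (Homo sapiens), read by mass spectrometry, with stated times of 60 min and 30 min; on this read-out higher numbers stand for weaker inhibition and lower numbers for stronger inhibition. Compound 1 `CCOc1cc(CN(C)C(=O)c2c(OCCCC3CCN(C(=O)OC(C)(C)C)CC3)c3ccccc3n(C)c2=O)cc(OCC)c1` gives 380 nM, compound 2 `CN(Cc1cc(C(F)(F)F)cc(C(F)(F)F)c1)C(=O)c1c(OCCCC2CCN(C(=O)OC3(C)CC3)CC2)c2cccnc2n(C)c1=O` gives 47 nM, and compound 3 `CN(Cc1cc(C(F)(F)F)cc(C(F)(F)F)c1)C(=O)c1c(OCCCC2CCCCC2)c2ccccc2n(C)c1=O` gives 480 nM. Compound 2 thus holds the lowest number of the three; compound 1 is nearest to it and compound 3 furthest, both gaps lying beyond the scatter. For the measured compounds named here, no pair among the measured compounds differs in one place only, so no single change can be read off directly.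

Compound 4 `COc1cc(CN(C)C(=O)c2c(OCCCC3CCN(C(=O)OC4(C)CC4)CC3)c3cccnc3n(C)c2=O)cc(C(F)(F)F)c1` is not yet measured. Relative to compound 2 the change is methoxy in place of trifluoromethyl on an aromatic carbon. Going by the values given here, the step from compound 2 to compound 4 is expected to be modest and to weaken inhibition, since the only nearby guide, compound 2 with 47 nM, carries the paired trifluoromethyl groups, whereas the ethoxy-bearing compound 1 sits far higher at 380 nM with several other changes confounding the comparison. For compound 4 the expected step is a 2.1-fold higher number from compound 2 to compound 4 (0.33 log units; beyond the scatter). The estimate for compound 4 in this assay is 100 nM, with a range from 35 nM to 300 nM.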

Compound 4, half-maximal inhibitory concentration in the phosphatidylcholine:ceramide cholinephosphotransferase 2 assay: 45 nM
For compound 4 the middle estimate is 2.2-fold (0.35 log units) above the measured one; low and high end bracket the measured number.
By their numbers in the phosphatidylcholine:ceramide cholinephosphotransferase 2 assay, from the lowest: compounds 4 and 2 (each within the scatter of the next); then compounds 1 and 3 (each within the scatter of the next).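

In the phosphatidylcholine:ceramide cholinephosphotransferase 2 assay, methoxy in place of one trifluoromethyl on this aromatic carbon gives a 1.0-fold lower number from compound 2 to compound 4 (0.02 log units; within the scatter), so at this core the paired trifluoromethyl groups are not both needed for a number at this level, which compound 1 and compound 3, each differing from compound 2 in more than one place, could not show. In a physicochemical assay for solubility, read by LC-MS, at pH 6.8 (a higher number here means a more soluble compound, a lower number a less soluble compound), the same change gives an at least 2.6-fold higher number from compound 2 to compound 4 (0.42 log units; beyond the scatter), and this step rests on a limit: the limit of < 0.3 ug/mL in the physicochemical assay, at which 1 of the 2 values shown sits. In the physicochemical assay compound 2 gives < 0.3 ug/mL, which is a limit of the assay and not a number. In the physicochemical assay compound 4 gives 0.79 ug/mL.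

Whether methoxy can also take the place of the remaining trifluoromethyl group is open. Also open, as far as these compounds go, is whether a nitrile, an amine or a carboxylic acid on this aromatic carbon would hold the number in the phosphatidylcholine:ceramide cholinephosphotransferase 2 assay.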